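Hydroxyphenyl for chlorophenyl on an amine-substituted aromatic core

The source may report more compounds than this note shows. Statements on the series, on what has been measured and on what is new or still open speak of the compounds shown alone.

Compound 1 `C#CCSc1nc(NCCC(C)C)c2ccncc2n1`: > 80000 nM (a limit of the assay)
Compound 2 `C#CCSc1nc(Nc2ccc(Cl)cc2)c2ccncc2n1`: 19000 nM
Compound 3 `C#CCSc1nc(Nc2cccc(O)c2)c2ccncc2n1`: not yet measured

In a functional assay on PC-3 cells (Homo sapiens) for inhibition, read by MTT assay, with a stated time of 72 h (on this read-out higher numbers stand for weaker inhibition and lower numbers for stronger inhibition), compound 1 gives > 80000 nM, which is a limit of the assay rather than a number (the limit of > 80000 nM in this assay, at which 1 of the 2 values shown sits). Among the measured compounds shown here, compound 2 is the only compound with a measured number in this assay, where compound 2 gives 19000 nM. The step of an at least 4.2-fold lower number from compound 1 to compound 2 (0.62 log units; beyond the scatter) is the only measured one, and it concerns an alkyl-to-aryl exchange on that nitrogen. Compound 3 differs from compound 2 by 3-hydroxyphenyl in place of 4-chlorophenyl on a nitrogen on an aromatic ring. For the measured compounds named here, no measured step compares one aryl group with another on this nitrogen, so the expectation for compound 3 rests mainly on compound 2. A step of about a 1.3-fold higher number from compound 2 to compound 3 (0.12 log units; within the scatter) is expected, which lies within the scatter. Compound 3 is therefore estimated at 25000 nM in this assay, with a range from 8000 nM to 80000 nM.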

Compound 3, half-maximal inhibitory concentration: > 80000 nM
Compound 3 was reported as a limit; the forecaster's own chance of this, stated with the estimate: 25%; middle value at least 3.2-fold (0.50 log units) from the limit.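

In this assay, putting 3-hydroxyphenyl in place of 4-chlorophenyl gives an at least 4.2-fold higher number from compound 2 to compound 3 (0.62 log units; beyond the scatter). The earlier step showed only an alkyl-to-aryl exchange on this nitrogen; this one shows that the choice of aryl group also matters, and that an aromatic ring here does not by itself secure a measurable number. Compound 3 gives > 80000 nM, which is a limit of the assay and not a number, and the step to it from compound 1 cannot be read, as the limit is now shared: the limit of > 80000 nM in this assay, at which 2 of the 3 values shown sit.

From the compounds shown here alone, compound 3 changes both the group on the ring and its place, so it remains open whether the hydroxyl or its place accounts for the step. Going by these compounds, how 4-hydroxyphenyl, 3-chlorophenyl or 4-methoxyphenyl on this nitrogen would compare with compound 2 also stays open.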